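A few compounds are considered here, and "the series" means these few. Any claim that something is new, unique, unknown or untested is made for them only; others in the source may bear on it.

Measured so far:
compound 1 `CN1CCN(c2ccc(-c3nc(-c4ccc(-c5nc(-c6ccc(F)cc6)c(-c6ccc(N7CCN(C)CC7)cc6)[nH]5)cc4)[nH]c3-c3ccc(F)cc3)cc2)CC1`: 12.7 degrees C
compound 2 `CN1CCN(c2ccc(-c3nc(-c4ccc(-c5nc(-c6ccc(F)cc6)c(-c6ccc(N7CCN(C)CC7)cc6)[nH]5)cc4)[nH]c3-c3ccc(N4CCN(C)CC4)cc3)cc2)CC1`: 15.7 degrees C

In an assay on nucleic acid for binding affinity to Quadruplex DNA (Homo sapiens), read by spectrophotometry and circular dichroism, tested at 6 uM (a higher number here means that the compound stabilises the target more against heat, a lower number that the compound stabilises the target less), compound 2 gives 15.7 degrees C, the higher of the two numbers; compound 1 gives 12.7 degrees C, a step below it that lies beyond the usual scatter. Compound 3 `CN1CCN(c2ccc(-c3nc(-c4ccc(-c5nc(-c6ccc(N7CCN(C)CC7)cc6)c(-c6ccc(N7CCN(C)CC7)cc6)[nH]5)cc4)[nH]c3-c3ccc(N4CCN(C)CC4)cc3)cc2)CC1` is the next step along the same line: 4-methylpiperazin-1-yl in place of fluoro on an aromatic carbon. Going by the values given here, the one measured step that bears on this change is a number 3.0 degrees C higher from compound 1 to compound 2 (beyond the scatter), the same kind of replacement. A rise of similar size is therefore expected, a number 2.8 degrees C higher from compound 2 to compound 3 (beyond the scatter). For compound 3 the estimate in this assay is 18.5 degrees C, with a range from 16.5 degrees C to 21 degrees C.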

Compound 3, shift of the target's melting temperature: 6.9 degrees C
Estimate against measurement, compound 3: 12 degrees C above; measured number below the stated range.
By their numbers in this assay, from the lowest: compound 3; then compound 1; then compound 2.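

In this assay, replacing the last fluoro with 4-methylpiperazin-1-yl gives a number 8.8 degrees C lower from compound 2 to compound 3 (beyond the scatter) and so runs opposite to the same kind of replacement earlier, a number 3.0 degrees C higher from compound 1 to compound 2 (beyond the scatter). The effect of this change therefore depends on where it is made or on what the molecule already carries, and one replacement does not predict the next. Nothing shown accounts for the reversal. On these data alone, it remains open whether a morpholine ring or a dimethylamino group in this place would give a number closer to that of compound 2 or to that of compound 3.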